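Swapping the Aniline Arm of a Weak Benzothiazole Pyrimidine

The source may hold more compounds than are shown below. What is called first, only, known or untested is meant among the compounds shown, and "the series" means these compounds.

Compound 1 `Cc1cnc(Nc2ccc(S(C)(=O)=O)cc2)nc1Nc1nc2ccc(Cl)cc2s1` shows the shared core with a methylsulfonylphenyl arm and a chloro group; in a functional assay on HCT-116 cells (Homo sapiens) for antiproliferative activity, read by MTT assay, with a stated time of 48 h (on this read-out lower numbers stand for stronger inhibition and higher numbers for weaker inhibition), compound 1 gives 2500 nM. Compound 3 `Cc1cnc(Nc2ccc(S(C)(=O)=O)cc2)nc1Nc1nc2ccc(F)cc2s1` differs only by the halogen, and in this assay compound 3 gives 24000 nM, a 9.6-fold higher number from compound 1 to compound 3 (0.98 log units; beyond the scatter). As far as these compounds go, compound 2 `Cc1cnc(Nc2ccc(C(C)C)cc2)nc1Nc1nc2ccccc2s1` carries a 4-isopropylphenyl arm and no halogen; in this assay compound 2 gives only a limit, > 50000 nM, so its true value is unknown, sitting at the limit of > 50000 nM in this assay, at which 1 of the 3 values shown sits. Compound 4 `COc1cccc(Nc2ncc(C)c(Nc3nc4ccccc4s3)n2)c1` differs from compound 2 by 3-methoxyphenyl in place of 4-isopropylphenyl on a nitrogen on an aromatic ring. Among the compounds with values here, no measured step touches this arm, so the halogen step offers no direct guide. The number for compound 4 in this assay is estimated at 30000 nM, between 5000 nM and 100000 nM. This expectation implies a step of an at least 1.6-fold lower number from compound 2 to compound 4 (0.22 log units; that floor lies within the scatter) from compound 2 to compound 4.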

Compound 4, half-maximal inhibitory concentration: > 50000 nM
Compound 4 ended at the assay's limit; the forecaster's own chance of this, stated with the estimate: 45%; middle value at least 1.6-fold (0.22 log units) from the limit.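

In this assay, compound 2 and compound 4 both stop at a limit rather than a number, so the step between them cannot be read: the limit of > 50000 nM in this assay, at which 2 of the 4 values shown sit. As far as these compounds go, whether 3-methoxyphenyl or 4-isopropylphenyl gives stronger inhibition stays open.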